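Nitro in place of methoxy on the pendant aryl

The source may hold more compounds than are shown below. What is called first, only, known or untested is meant among the compounds shown, and "the series" means these compounds.

Measured so far:
compound 1 `Cc1ccc(-c2ccc([N+](=O)[O-])cc2)n1-c1ccc(-c2nc3ccccc3s2)cc1` — 2540 nM
compound 2 `Cc1ccc(-c2ccc(F)cc2)n1-c1ccc(-c2nc3ccc(F)cc3s2)cc1` — 1790 nM
compound 3 `COc1ccc(-c2ccc(C)n2-c2ccc(-c3nc4ccc(F)cc4s3)cc2)cc1` — 2120 nM

In a functional assay on MCF7 cells (Homo sapiens) for cytotoxicity, read by sulforhodamine B assay, with a stated time of 48 h (on this read-out lower numbers stand for stronger inhibition of growth and higher numbers for weaker inhibition of growth), compound 3 gives 2120 nM. Compound 3 stands between the other two on the numbers shown, and all three values lie within the scatter of one another, so none can be called stronger or weaker than another. Within the data shown here, the one measured step, a 1.2-fold higher number from compound 2 to compound 3 (0.07 log units; within the scatter), changed nothing beyond the scatter.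

Compound 4 `Cc1ccc(-c2ccc([N+](=O)[O-])cc2)n1-c1ccc(-c2nc3ccc(F)cc3s2)cc1` differs from compound 3 in one place: nitro in place of methoxy on an aromatic carbon. Among the measured compounds shown here, no measured step covers a nitro group entering, so there is no direct precedent. What can be said is that compound 1 carries the same nitro group and gives 2540 nM, a number within the scatter of compound 3. The step from compound 2 to compound 3 shows that swapping a group on this aryl ring moved the number little. Compound 4 is therefore expected to land near compound 3, with a step of a 1.1-fold higher number from compound 3 to compound 4 (0.04 log units; within the scatter) that is expected to stay within the scatter. The estimate for compound 4 is 2300 nM, with a range from 1200 nM to 4500 nM.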

Compound 4, concentration for 50% growth inhibition: 918 nM
For compound 4 the middle estimate is 2.5-fold (0.40 log units) above the measured one, and the stated range ends above it.
By their numbers in this assay, from the lowest: compounds 4, 2, 3 and 1 (each within the scatter of the next, the first and the last beyond it).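

At this position the group does matter: in this assay, the change from 4-methoxyphenyl to 4-nitrophenyl gives a 2.3-fold lower number from compound 3 to compound 4 (0.36 log units; beyond the scatter), a clearer move than any step measured before. Set against fluoro, however, the same nitro gives a 1.9-fold lower number from compound 2 to compound 4 (0.29 log units; within the scatter), so on these numbers nitro stands apart from methoxy but not from fluoro. Nitro also does not act alone in this series, since fluoro in place of hydrogen on the core, with the nitro group kept, gives a 2.8-fold lower number from compound 1 to compound 4 (0.44 log units; beyond the scatter), showing that a second place on the molecule also moves the number.

No measurement here bears on why these changes move the number. Open too, as far as these compounds go, is how an amine or a carboxylic acid would compare with nitro on this aryl ring, and whether the step from methoxy to nitro holds on the core without fluoro.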